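The compounds below may be only part of what the source reports. "The series", "measured", "known", "first", "only" and "open" are said of these compounds alone.

Measured in a functional assay on MCF7 cells (Homo sapiens) for inhibition, read by CCK-8 assay, with a stated time of 48 h; a higher number here means a weaker inhibitor of growth, a lower number a stronger inhibitor of growth:
- Compound 1 `Cc1ccccc1Nc1nc(NCc2ccccc2)ncc1Cl`: > 100000 nM, a limit of the assay
- Compound 2 `Cc1ccccc1Nc1nc(NCc2ccco2)ncc1Cl`: > 100000 nM, a limit of the assay
- Compound 3 `Cc1ccccc1Nc1nc(Nc2ccccn2)ncc1Cl`: 31400 nM

Compound 3 alone has a true number, while the other two compounds stand at one limit (the limit of > 100000 nM in this assay, at which 2 of the 3 values shown sit). Compound 4 `Cc1ccccc1Nc1nc(NCc2ccncc2)ncc1Cl` carries (pyridin-4-yl)methyl in place of pyridin-2-yl on a nitrogen on an aromatic ring. Like compound 1 and compound 2, it has its ring on a saturated chain carbon. For the measured compounds named here, two measured steps bear on this change when read in reverse: an at least 3.1-fold lower number from compound 1 to compound 3 (0.50 log units; beyond the scatter) and an at least 3.1-fold lower number from compound 2 to compound 3 (0.50 log units; beyond the scatter). A modest move to a higher number in this assay is therefore expected, possibly reaching the limit. The expected change is a 2.7-fold higher number from compound 3 to compound 4 (0.43 log units; beyond the scatter). For compound 4 the estimate is 85000 nM, with an expected range from 35000 nM to 150000 nM.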

Compound 4, concentration for 50% growth inhibition: > 100000 nM
Compound 4: a limit, no number (the forecaster's own chance of this, stated with the estimate: 60%); middle value at least 1.1-fold (0.07 log units) from the limit.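

In this assay the change gives an at least 3.1-fold higher number from compound 3 to compound 4 (0.50 log units; beyond the scatter), so a pyridine ring carried on a saturated chain carbon does not keep the number of compound 3. Among the compounds shown, only compound 3, with its ring directly on the nitrogen, gives a true number. The steps from compound 1 and compound 2 to compound 4 cannot be read: the limit of > 100000 nM in this assay, at which 3 of the 4 values shown sit.

The change alters both the chain and the ring attachment, and the compounds shown do not separate the two. Pyridin-4-yl directly on the nitrogen, or (pyridin-2-yl)methyl, would bear on this.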